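Triazole substituent change on the shared lactone core

This account rests on a few compounds, and the source may have more. Where it says the series, first, only, none or still open, it means among the compounds named here.

Two close analogues on the shared core have been measured. Compound 1 `O=C1O[C@H]([C@@H](O)Cn2cc(-c3cc(C(F)(F)F)cc(C(F)(F)F)c3)nn2)C(OCc2ccccc2)=C1OCc1ccccc1` gives 66500 nM in a functional assay on CFPAC-1 cells (Homo sapiens) for antiproliferative activity, read by MTT assay, with a stated time of 72 h (a lower number here means a stronger inhibitor, a higher number a weaker inhibitor), and compound 2 `CCCCc1cn(C[C@H](O)[C@H]2OC(=O)C(OCc3ccccc3)=C2OCc2ccccc2)nn1` gives 73200 nM. Compound 2 thus holds the highest number of the two, but compound 1 is within the scatter of it, so no order between them can be read. Both numbers sit at the weak end of the assay.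

Compound 3 `COc1ccc(-c2cn(C[C@H](O)[C@H]3OC(=O)C(OCc4ccccc4)=C3OCc3ccccc3)nn2)cc1` follows from compound 2 by 4-methoxyphenyl in place of butyl on an aromatic carbon. Within the data shown here, no step between measured compounds isolates this change. Among the measured compounds shown here, the only comparison available, compound 1 against compound 2, shows an aromatic ring and a butyl chain at this position giving numbers within the scatter of each other, so the step of a 1.2-fold lower number from compound 2 to compound 3 (0.09 log units; within the scatter) is expected to stay small, with no direction beyond the scatter. Compound 3 is estimated at 60000 nM, with a range from 25000 nM to 150000 nM.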

Compound 3, half-maximal inhibitory concentration: 26000 nM
The estimate for compound 3 lay 2.3-fold (0.36 log units) above the measured number, and the stated range covers the measured number.
By their numbers in this assay, from the lowest: compound 3; then compounds 1 and 2 (each within the scatter of the next).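

At this aromatic carbon, 4-methoxyphenyl in place of butyl gives a 2.8-fold lower number from compound 2 to compound 3 (0.45 log units; beyond the scatter) in this assay, so the substituent here can move the number beyond the scatter, which the close values of compounds 1 and 2 did not show. The step is modest, and compound 3 at 26000 nM remains a weak inhibitor. Nothing in the data at hand accounts for the step.

Still open, from the compounds shown here alone, is whether the step belongs to the aromatic ring or to the methoxy group, a question that an unsubstituted phenyl at this carbon would separate. Also open, going by these compounds, is how the number would respond to a 4-hydroxyphenyl, or to an amine or a carboxylic acid carried on the ring.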